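A few compounds are considered here, and "the series" means these few. Any claim that something is new, unique, unknown or untested is made for them only; others in the source may bear on it.

In an ADME assay on microsomes from liver (Mus musculus, strain CD1) for metabolic stability, read by LC-MS, with a stated time of 1 h (on this read-out lower numbers stand for a less stable compound and higher numbers for a more stable compound), compound 1 `O=[N+]([O-])c1cn2c(n1)OC[C@@H](OCc1ccc(-c3ccc(C(F)(F)F)cc3)cc1)C2` gives 85% and compound 2 `O=[N+]([O-])c1cn2c(n1)OC[C@@H](OCc1ccc(-c3ccc(C(F)(F)F)cc3Cl)cc1)C2` gives 93%, two values within the scatter of each other. Compound 3 `COc1cccc(F)c1-c1ccc(CO[C@@H]2COc3nc([N+](=O)[O-])cn3C2)cc1` departs from compound 1 as follows: 2-fluoro-6-methoxyphenyl in place of 4-(trifluoromethyl)phenyl on an aromatic carbon. Here 2-fluoro-6-methoxyphenyl stands in place of 4-(trifluoromethyl)phenyl on an aromatic carbon. For the measured compounds named here, the one measured step, a number 8 percentage points higher from compound 1 to compound 2 (within the scatter), puts chloro in place of hydrogen and does not replace this group, so it offers only a weak guide. With compound 1 at 85%, more room lies downward, and a moderate fall beyond the scatter is expected, as a number 15 percentage points lower from compound 1 to compound 3 (beyond the scatter). For compound 3 the estimate is 70%, with an expected range of 45% to 92%.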

Compound 3, percent of the compound remaining: 0%
The estimate for compound 3 lay 70 percentage points above the measured number; measured number outside the range, below it.
By their numbers in this assay, from the lowest: compound 3; then compounds 1 and 2 (each within the scatter of the next).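

In this assay the group on this aromatic carbon turns out to matter greatly: with 2-fluoro-6-methoxyphenyl in place of 4-(trifluoromethyl)phenyl, the result is a number 85 percentage points lower from compound 1 to compound 3 (beyond the scatter) and this large step contrasts with the chloro change, which stayed within the scatter. No evidence at hand accounts for this loss.

The compounds shown leave open whether the methoxy or the fluorine goes with the step, as both enter together while trifluoromethyl leaves. On these data alone, how a nitrile or an amine would fare at this place also remains open.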